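This account rests on a few compounds, and the source may have more. Where it says the series, first, only, none or still open, it means among the compounds named here.

Compound 2 `O=C(CN1CCN(c2nnc(Cc3ccncc3)c3ccccc23)CC1)Nc1ccc(Br)cc1` gives the lowest number among the three measured compounds in a functional assay on MDA-MB-231 cells (Homo sapiens) for cytotoxicity, read by MTT assay, with a stated time of 72 h (on this read-out lower numbers stand for stronger inhibition and higher numbers for weaker inhibition), at 19 nM. Compound 1 `O=C(CN1CCN(c2nnc(Cc3ccccc3)c3ccccc23)CC1)Nc1c(F)cccc1F` gives 5490 nM and compound 3 `O=C(CN1CCN(c2nnc(Cc3ccccc3)c3ccccc23)CC1)Nc1ccc(Br)cc1` gives 12400 nM; the step of a 650-fold higher number from compound 2 to compound 3 (2.81 log units; beyond the scatter) is large, while a 2.3-fold higher number from compound 1 to compound 3 (0.35 log units; beyond the scatter) is modest. Compound 4 `O=C(CN1CCN(c2nnc(Cc3ccncc3)c3ccccc23)CC1)Nc1ccc(F)c(F)c1` differs from compound 2 only at the amide end: 3,4-difluorophenyl in place of 4-bromophenyl on an amide-type nitrogen. Among the measured compounds shown here, the one measured step that changes the aryl group on this amide-type nitrogen, a 2.3-fold higher number from compound 1 to compound 3 (0.35 log units; beyond the scatter), moved the number only a little, and it involved a different difluorophenyl pattern, so it offers only loose guidance. Compound 4 is therefore expected to show a 1.3-fold lower number from compound 2 to compound 4 (0.10 log units; within the scatter), a step within the scatter. The estimate for compound 4 is 15 nM, within 5 nM to 60 nM.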

Compound 4, half-maximal inhibitory concentration: 0.84 nM
Compound 4: the middle estimate sits 18-fold (1.25 log units) above what was measured, and the stated range ends above it.
By their numbers in this assay, from the lowest: compound 4; then compound 2; then compound 1; then compound 3.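

In this assay, among the compounds shown here, the aryl group on the amide-type nitrogen matters far more than the earlier step (a 2.3-fold higher number from compound 1 to compound 3 (0.35 log units; beyond the scatter)) suggested, since 3,4-difluorophenyl in place of 4-bromophenyl gives a 23-fold lower number from compound 2 to compound 4 (1.35 log units; beyond the scatter) and reaches the lowest number so far. That earlier step carried phenyl rather than pyridin-4-yl on the saturated chain carbon and a different difluorophenyl pattern, so the two steps are not the same change. Nothing available gives a reason for this gain.

Going by these compounds, whether 3,4-difluorophenyl would help as much with phenyl in that place stays open. So does how 4-fluorophenyl, 4-chlorophenyl or 4-methoxyphenyl would fare on the amide-type nitrogen.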